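A few compounds are considered here, and "the series" means these few. Any claim that something is new, unique, unknown or untested is made for them only; others in the source may bear on it.

Three compounds have been measured in a functional assay on HEK293 cells for antagonist activity at transient receptor potential M8 protein (Canis lupus familiaris), read by FLIPR and calcium flux; a higher number here means a weaker inhibitor, a lower number a stronger inhibitor:

Compound 1 `Fc1ccccc1-c1ccc2[nH]c(C3=NOC4(CCCCC4)C3)nc2c1`: 2.9 nM
Compound 2 `Fc1cccc(C(F)(F)F)c1-c1ccc2[nH]c(C3=NOC4(CCCCC4)C3)nc2c1`: 0.6 nM
Compound 3 `Fc1ccccc1-c1cc(C(F)(F)F)c2[nH]c(C3=NOC4(CCCCC4)C3)nc2c1`: 1.7 nM

Among these three, compound 1 has the highest number. Adding a trifluoromethyl to the pendant ring gave a 4.8-fold lower number from compound 1 to compound 2 (0.68 log units; beyond the scatter), while adding a trifluoromethyl to the shared core gave a 1.7-fold lower number from compound 1 to compound 3 (0.23 log units; within the scatter).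

Compound 4 `CC(C)(O)c1ccccc1-c1ccc2[nH]c(C3=NOC4(CCCCC4)C3)nc2c1` keeps the same core but alters the pendant ring in a different way: 1-hydroxy-1-methylethyl in place of fluoro on an aromatic carbon. Neither measured step concerns this position or this kind of group; both replaced a hydrogen with trifluoromethyl elsewhere, and both lowered or left the number unchanged. The change to compound 4 removes the fluoro and brings in a larger group carrying one hydrogen-bond donor and one acceptor, ortho to a large group, so the measured steps offer only loose guidance. Given that the small changes seen so far stayed within a modest range, compound 4 is expected to remain a potent inhibitor, with an estimated step of a 2.1-fold higher number from compound 1 to compound 4 (0.32 log units; beyond the scatter), most likely a somewhat higher number in this assay. The estimate for compound 4 in this assay is 6 nM, within a range from 1.5 nM to 30 nM.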

Compound 4, half-maximal inhibitory concentration: 7.9 nM
The estimate for compound 4 lay 1.3-fold (0.12 log units) below the measured number, within the range that was stated.
By their numbers in this assay, from the lowest: compound 2; then compounds 3 and 1 (each within the scatter of the next); then compound 4.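

In this assay, within the data shown here, replacing fluoro with 1-hydroxy-1-methylethyl on an aromatic carbon, ortho to a large group, gives a 2.7-fold higher number from compound 1 to compound 4 (0.44 log units; beyond the scatter), the first step that raises the number beyond the scatter. Among these compounds, the earlier steps only put trifluoromethyl in place of hydrogen, so this is the first view of what happens when the fluoro itself leaves and a group of 4 heavy atoms, with a hydrogen-bond donor and a hydrogen-bond acceptor, enters; the step is modest, and compound 4 still gives 7.9 nM, so this place accepts a much larger group without a collapse in inhibition. No measurement here explains the rise, which remains an observation without a known cause.

This single change removes one group and adds another, so the compounds shown leave open whether the rise follows the loss of fluoro, the hydroxyl or the carbon framework of the new group. A tert-butyl group and a hydroxymethyl group at this place would help separate those possibilities, while an amine or a carboxylic acid would show how the assay responds to quite different groups there.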